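The source may report more compounds than this note shows. Statements on the series, on what has been measured and on what is new or still open speak of the compounds shown alone.

Two compounds set the scene. Compound 1 `CCN(C/C=C/C#CC(C)(C)C)Cc1cccc(OCCN(C)S(=O)(=O)c2cccs2)c1` gives 60 nM in a functional assay on HepG2 cells for inhibition of squalene monooxygenase (Homo sapiens); a higher number here means a weaker inhibitor, a lower number a stronger inhibitor. Going by the values given here, compound 2 `CCN(C/C=C/C#CC(C)(C)C)Cc1cccc(OCCN(C)S(=O)(=O)c2cccnc2)c1` gives 150 nM in this assay, which is the highest of the two numbers, and the one measured step, a 2.5-fold higher number from compound 1 to compound 2 (0.40 log units; beyond the scatter), separates it from compound 1. Compound 3 `CCN(C/C=C/C#CC(C)(C)C)Cc1cccc(OCCN(C)S(=O)(=O)c2cc(Br)cs2)c1` follows from compound 2 by a single change: 4-bromothiophen-2-yl in place of pyridin-3-yl on a sulfonyl sulfur. Among the compounds with values here, only that measured step bears on this change, and it does so in reverse, as compound 3 carries a 4-bromothiophen-2-yl group on the sulfonyl sulfur where compound 1 carried a plain thiophen-2-yl group; that step was modest but beyond the scatter. A step back down in this assay of roughly the same size is therefore expected, a 2.5-fold lower number from compound 2 to compound 3 (0.40 log units; beyond the scatter). Compound 3 is estimated at 60 nM, with a range from 20 nM to 180 nM.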

Compound 3, half-maximal inhibitory concentration: 300 nM
Estimate against measurement, compound 3: 5.0-fold (0.70 log units) below; measured number above the stated range.
By their numbers in this assay, from the lowest: compound 1; then compounds 2 and 3 (each within the scatter of the next).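

The exchange on the sulfonyl sulfur in this assay, a 2.0-fold higher number from compound 2 to compound 3 (0.30 log units; within the scatter), shows that pyridin-3-yl and 4-bromothiophen-2-yl cannot be told apart at this position. A thiophene ring on the sulfonyl sulfur is therefore not enough to hold the lower number of compound 1. Bromo in place of hydrogen on an aromatic carbon gives a 5.0-fold higher number from compound 1 to compound 3 (0.70 log units; beyond the scatter), a modest step beyond the scatter that is the first measured effect of a substituent on this ring (nothing shown here accounts for it).

The compounds shown leave open whether chloro or methyl in place of the bromo would give the same step. They also leave open whether a plain phenyl ring on the sulfonyl sulfur would stand nearer to thiophen-2-yl or to pyridin-3-yl.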